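Formyl Swapped for Ethynyl on a Weakly Cytotoxic Core

This account rests on a few compounds, and the source may have more. Where it says the series, first, only, none or still open, it means among the compounds named here.

Within the data shown here, in a functional assay on A549 cells (Homo sapiens) for cytotoxicity, read by MTT assay, with a stated time of 48 h (a higher number here means a weaker inhibitor, a lower number a stronger inhibitor), compound 1 `C=C1CCC[C@]2(C)CCC(C=O)=CC[C@@]12C` gives 145000 nM while compound 2 `CC1(C)CCCC2=CC=C(C=O)CC[C@]21C` gives 138000 nM and these two numbers lie within the usual scatter, so compound 1 stands level with the only other measured compound. Compound 3 `C#CC1=CC[C@@]2(C)C(=C)CCC[C@]2(C)CC1` keeps the core of compound 1 but carries ethynyl in place of formyl on a double-bonded ring carbon and still awaits measurement. Among the measured compounds shown here, no measured pair shows this change, so no step beyond the scatter is expected. The estimated step is a 1.2-fold lower number from compound 1 to compound 3 (0.08 log units; within the scatter) and remains uncertain. Compound 3 is expected at 120000 nM with an estimated range from 45000 nM to 300000 nM for now.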

Compound 3, half-maximal inhibitory concentration: 148000 nM
The estimate for compound 3 lay 1.2-fold (0.09 log units) below the measured number, within the range that was stated.
By their numbers in this assay, from the lowest: compounds 2, 1 and 3 (each within the scatter of the next).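

In this assay, ethynyl in place of formyl on a double-bonded ring carbon gives a 1.0-fold higher number from compound 1 to compound 3 (0.01 log units; within the scatter) and so leaves the number level. This pair shows that the formyl oxygen, counted as a hydrogen-bond acceptor, can leave this position without any change that stands out from the scatter. No measurement here explains why the two compounds stand level. From the compounds shown here alone, it remains open whether an amine or a carboxylic acid on this ring carbon of the shared core would move the number beyond the scatter.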